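The source may report more compounds than this note shows. Statements on the series, on what has been measured and on what is new or still open speak of the compounds shown alone.

In an ADME assay on HepG2 2.2.15 cells (Homo sapiens) for cytotoxicity, read by MTT assay, with stated times of 48 h and 9 days (on this read-out higher numbers stand for lower toxicity in this test and lower numbers for higher toxicity in this test), compound 1 `COc1ccc2c(=O)c(/C=C/C(=O)Nc3cccc(C)c3)coc2c1` gives 554000 nM and compound 2 `COc1ccc2c(=O)c(/C=C/C(=O)Nc3ccccc3Cl)coc2c1` gives 1010000 nM. Compound 3 `COc1ccc(CNC(=O)/C=C/c2coc3cc(OC)ccc3c2=O)cc1`, with 4-methoxybenzyl on the amide nitrogen, gives 43000 nM, the lowest number of the three. Compound 4 `COc1ccc2c(=O)c(/C=C/C(=O)NCc3ccc(C)cc3)coc2c1` has methyl in place of methoxy on an aromatic carbon, turning 4-methoxybenzyl into 4-methylbenzyl (methyl in place of methoxy on an aromatic carbon). Going by the values given here, no measured step makes this exact swap. The large steps, a 13-fold lower number from compound 1 to compound 3 (1.11 log units; beyond the scatter) and a 23-fold lower number from compound 2 to compound 3 (1.37 log units; beyond the scatter), replaced the whole group on the amide nitrogen, a far bigger change. The step of a 1.8-fold higher number from compound 1 to compound 2 (0.26 log units; within the scatter) swapped both the group and its position on the aromatic ring, yet stayed small. In this assay, the expected step is therefore a 1.3-fold higher number from compound 3 to compound 4 (0.11 log units; within the scatter), with no clear change anticipated. The estimate for compound 4 is 55000 nM, with an expected range of 20000 nM to 150000 nM.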

Compound 4, half-maximal cytotoxic concentration: 257000 nM
Compound 4: the middle estimate sits 4.7-fold (0.67 log units) below what was measured; the whole stated range lies below it.
By their numbers in this assay, from the lowest: compound 3; then compound 4; then compounds 1 and 2 (each within the scatter of the next).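

In this assay, methyl in place of methoxy gives a 6.0-fold higher number from compound 3 to compound 4 (0.78 log units; beyond the scatter) on this one aromatic position, so a change of a single small group here counts. With 4-methylbenzyl on the amide nitrogen, the number still falls, with a 3.9-fold lower number from compound 2 to compound 4 (0.59 log units; beyond the scatter) and a 2.2-fold lower number from compound 1 to compound 4 (0.33 log units; beyond the scatter) as modest steps, smaller than the large steps to compound 3. No supporting evidence explains the methoxy-to-methyl difference. On these data alone, whether a hydroxyl, an amine or a longer chain such as ethoxy at this position would sit nearer compound 3 or compound 4 remains open.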